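This account rests on a few compounds, and the source may have more. Where it says the series, first, only, none or still open, it means among the compounds named here.

Compound 1 `COCCOc1cc(/C=C/c2ccc3ccccc3c2)ccc1OC`: > 5000 nM
Compound 2 `COc1ccc(/C=C/c2ccc3ccccc3c2)cc1[N+](=O)[O-]`: > 5000 nM
Compound 3 `C(=C\c1ccco1)\c1ccc2ccccc2c1`: > 5000 nM

These results come from a functional assay on HT-29 cells (Homo sapiens) for inhibition (a lower number here means a stronger inhibitor, a higher number a weaker inhibitor), and none of them is a number. The overall picture is the limit of > 5000 nM in this assay, at which 3 of the 3 values shown sit. Compound 3 gives > 5000 nM, which is a limit of the assay. It therefore cannot be ranked against compound 1 or compound 2.

Compound 4 `C(=C\c1ccc2ccccc2c1)\c1ccoc1`, not yet measured, has the same atoms as compound 3, joined differently: furan-3-yl in place of furan-2-yl on a double-bonded chain carbon bound to a double-bonded chain carbon. The change is furan-3-yl in place of furan-2-yl on a double-bonded chain carbon bound to a double-bonded chain carbon.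

Among the measured compounds shown here, only one measured step is available, a step that the two limits leave unreadable from compound 1 to compound 2. It involves a different change, nitro in place of 2-methoxyethoxy, and its size cannot be read, so it offers no size to carry over. For the measured compounds named here, no compound in the set shows a number in this assay, and no furan-3-yl compound has been measured. No step beyond the usual scatter is therefore expected, and compound 4 is expected to be reported as a limit as well. That expectation rests on compound 3, with its > 5000 nM. The expected step, a step that the limit leaves unreadable from compound 3 to compound 4, is only an estimate set against a limit. For compound 4 the estimated value is 7000 nM, with an expected range from 2500 nM to 20000 nM.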

Compound 4, half-maximal inhibitory concentration: > 5000 nM
Compound 4: no number, only a limit; the forecaster's own chance of this, stated with the estimate: 85%; the middle value is on the limit's open side.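

In this assay compound 4 gives > 5000 nM, which is a limit of the assay and not a number. Compound 3 also stands at a limit, so the step between compound 3 and compound 4 cannot be read. The whole series reads alike: the limit of > 5000 nM in this assay, at which 4 of the 4 values shown sit. The compounds shown leave open how far any of them lies from that limit, and whether furan-3-yl and furan-2-yl differ at all.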